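This account rests on a few compounds, and the source may have more. Where it says the series, first, only, none or still open, it means among the compounds named here.

In a functional assay (strain AB) with Danio rerio as the target, read by microscopy, with a stated time of 1 h (a higher number here means that more compound is needed for the effect, a lower number that less compound is needed), compound 1 (`CCN1CCc2c(sc(NC(=O)Nc3ccc(Cl)cc3)c2C(=O)NC)C1`) gives > 25000 nM, which is a limit of the assay and not a number. Compound 2 (`CCN1CCc2c(sc(NC(=O)Nc3ccc(Cl)cc3)c2C(=O)O)C1`) gives > 25000 nM, again a limit. Compound 3 (`CCN1CCc2c(sc(NC(=O)Nc3ccc(Cl)cc3)c2C(=O)c2nc(C)no2)C1`) gives > 25000 nM, also a limit. Among the measured compounds shown here, the series so far shows no number, only (the limit of > 25000 nM in this assay, at which 3 of the 3 values shown sit).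

Compound 4 (`CCN1CCc2c(sc(NC(=O)Nc3ccc(Cl)cc3)c2C(=O)c2nnco2)C1`) differs from compound 3 on the carbonyl carbon: 1,3,4-oxadiazol-2-yl in place of 3-methyl-1,2,4-oxadiazol-5-yl on a carbonyl carbon.

The measured steps at this place are a step that the two limits leave unreadable from compound 1 to compound 2, a step that the two limits leave unreadable from compound 1 to compound 3 and a step that the two limits leave unreadable from compound 2 to compound 3. None gives a size, so no step beyond the scatter and no direction is expected in this assay.

For compound 4 the estimated value is 25000 nM, with an expected range from 10000 nM to 50000 nM. The expected change is a number no higher from compound 3 to compound 4 (the limit leaves the size open).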

Compound 4, half-maximal effective concentration: > 25000 nM
Compound 4 was reported as a limit; the forecaster's own chance of this, stated with the estimate: 85%; the middle value lies on the limit itself.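

Compound 4 gives > 25000 nM in this assay, a limit and not a number, and its steps to compound 1, compound 2 and compound 3 cannot be read. Still open is whether any group on the carbonyl carbon gives a measurable value in this assay: the limit of > 25000 nM in this assay, at which 4 of the 4 values shown sit.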